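The compounds below may be only part of what the source reports. "The series", "measured", "known", "first", "only" and "open" are said of these compounds alone.

Compound 1 `CC(=O)Nc1cc(NC(=O)Nc2cc(C(F)(F)F)cc(C(F)(F)F)c2)ccc1C` and compound 2 `Cc1ccc(NC(=O)Nc2cc(C(F)(F)F)cc(C(F)(F)F)c2)cc1NC(=O)c1ccccc1` share one core, while compound 3 `CC(=O)Nc1cc(NC(=O)c2cc(=O)c3ccccc3o2)ccc1C` and compound 4 `Cc1ccc(NC(=O)c2cc(=O)c3ccccc3o2)cc1NC(=O)c1ccccc1` share another; the difference between the two cores is not broken down here. In a functional assay on A375P cells (Homo sapiens) for antiproliferative activity (a higher number here means a weaker inhibitor, a lower number a stronger inhibitor), compound 1 gives 685 nM. In this assay compound 2 gives 162 nM. The change between them is phenyl in place of methyl on a carbonyl carbon and it made a 4.2-fold lower number from compound 1 to compound 2 (0.63 log units; beyond the scatter). Compound 3 gives only a limit in this assay, > 30000 nM, one of the limit of > 30000 nM in this assay, at which 1 of the 3 values shown sits. Compound 4 carries the same change on the other core, (phenyl in place of methyl on a carbonyl carbon). Because compound 3 sits at > 30000 nM, the step from compound 3 to compound 4 is expected to be an at least 2.0-fold lower number from compound 3 to compound 4 (0.30 log units; that floor lies within the scatter), in keeping with a 4.2-fold lower number from compound 1 to compound 2 (0.63 log units; beyond the scatter), but the starting point is uncertain. Compound 4 is therefore estimated at 15000 nM, between 3000 nM and 60000 nM.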

Compound 4, half-maximal inhibitory concentration: > 30000 nM
Compound 4: a limit, no number; the forecaster's own chance of this, stated with the estimate: 40%; at least 2.0-fold (0.30 log units) between middle value and limit.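

Going by these compounds alone, no step from compound 3 to compound 4 can be read, because both compounds stand at a limit: the limit of > 30000 nM in this assay, at which 2 of the 4 values shown sit. As far as these compounds go, whether phenyl in place of methyl on a carbonyl carbon changes activity on the core of compound 3 stays open.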